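Hydroxyethyl chain at the ring methyl position: compound 4

This account rests on a few compounds, and the source may have more. Where it says the series, first, only, none or still open, it means among the compounds named here.

Compound 1 `COC(=O)CCCc1onc(NS(=O)(=O)c2ccc(C(C)(C)C)cc2)c1Sc1cccc(OC)c1`: 400 nM
Compound 2 `COc1cccc(Sc2c(NS(=O)(=O)c3ccc(C(C)(C)C)cc3)noc2CCCCC=O)c1`: 1400 nM
Compound 3 `COc1cccc(Sc2c(NS(=O)(=O)c3ccc(C(C)(C)C)cc3)noc2C)c1`: 530 nM

In an assay on A7R5 cells for displacement of a labelled ligand from Endothelin-1 receptor (Rattus norvegicus) (on this read-out lower numbers stand for stronger inhibition and higher numbers for weaker inhibition), compound 3 stands second highest of the three numbers; its nearest neighbour is compound 1, with the step of a 1.3-fold higher number from compound 1 to compound 3 (0.12 log units; within the scatter) lying within the scatter, and its furthest is compound 2, with a 2.6-fold lower number from compound 2 to compound 3 (0.42 log units; beyond the scatter) beyond it. Compound 4 `COc1cccc(Sc2c(NS(=O)(=O)c3ccc(C(C)(C)C)cc3)noc2CCO)c1` differs from compound 3 by hydroxymethyl in place of hydrogen on a saturated chain carbon bound to an aromatic carbon; cut one bond further out, the same difference reads methyl to 2-hydroxyethyl. For the measured compounds named here, two measured steps bear on this place: a 1.3-fold higher number from compound 1 to compound 3 (0.12 log units; within the scatter) shows that a longer chain with a methoxycarbonyl end changes nothing beyond the scatter, while a 2.6-fold lower number from compound 2 to compound 3 (0.42 log units; beyond the scatter) shows that a longer chain with a formyl end gives a modestly higher number. A short hydroxyethyl chain is therefore expected to give at most a small step upward in this assay, a 1.2-fold higher number from compound 3 to compound 4 (0.09 log units; within the scatter), and compound 4 is estimated at 650 nM within 280 nM to 1500 nM.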

Compound 4, half-maximal inhibitory concentration: 770 nM
Compound 4: the middle estimate sits 1.2-fold (0.07 log units) below what was measured, and the stated range covers the measured number.
By their numbers in this assay, from the lowest: compounds 1, 3, 4 and 2 (each within the scatter of the next, the first and the last beyond it).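

In this assay, the 2-hydroxyethyl chain in place of methyl gives no change beyond the scatter, a 1.5-fold higher number from compound 3 to compound 4 (0.16 log units; within the scatter), so this position accepts a short chain carrying a hydroxy. Compound 4 also stays within the scatter of both longer-chain compounds, with a 1.8-fold lower number from compound 2 to compound 4 (0.26 log units; within the scatter) and a 1.9-fold higher number from compound 1 to compound 4 (0.28 log units; within the scatter), so it cannot be separated from either, although those two lie beyond the scatter of each other. Nothing available explains these numbers. The compounds shown leave open whether an amine or a carboxylic acid in place of the hydroxy, or a hydroxy on a longer chain, would give a step beyond the scatter.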